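The compounds below may be only part of what the source reports. "The series", "measured", "known", "first", "only" and "open" are said of these compounds alone.

Of the compounds shown here, three have been measured in a physicochemical assay for permeability, using PAMPA, with a stated time of 4 h, at pH 7.4, tested at 50 uM; on this read-out lower numbers stand for lower permeability and higher numbers for higher permeability. Compound 1 `Cc1c(Cl)cccc1CCCCOc1ccc(C#Cc2cccc3c(CCCC(=O)O)c(C)n(CC(=O)O)c23)cc1` gives 3.2 10^-6 cm/s. Compound 2 `Cc1c(Cl)cccc1CCCCOc1ccc(C#Cc2cccc3c(CCCC(=O)O)c(C)n(CCC(=O)O)c23)cc1` differs from compound 1 by a single change, (carboxymethyl in place of carboxy on a saturated chain carbon bound to an aromatic nitrogen). In this assay compound 2 gives 3 10^-6 cm/s; that change made a 1.1-fold lower number from compound 1 to compound 2 (0.03 log units; within the scatter). Compound 3 `Cc1c(Cl)cccc1CCCCOc1ccc(C#Cc2cccc3c(CC(=O)O)c(C)n(CCCCC(=O)O)c23)cc1` gives 1 10^-6 cm/s, the lowest of the three numbers, with both compound 1 and compound 2 standing above it by more than the scatter. Compound 3 shares much of its shape with compound 1 but differs from it in more than one place, and the difference between the two cores is not broken down here.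

Compound 4 `Cc1c(Cl)cccc1CCCCOc1ccc(C#Cc2cccc3c(CCC(=O)O)c(C)n(CCCCC(=O)O)c23)cc1` has not yet been measured in this assay. It differs from compound 3 by carboxymethyl in place of carboxy on a saturated chain carbon bound to an aromatic carbon. Among the compounds with values here, this is the same kind of change as the one between compound 1 and compound 2, but not the same: there the carboxy sat on a saturated chain carbon bound to an aromatic nitrogen, here it sits on a saturated chain carbon bound to an aromatic carbon. For compound 4 a step of about a 1.2-fold higher number from compound 3 to compound 4 (0.08 log units; within the scatter) is expected, because a 1.1-fold lower number from compound 1 to compound 2 (0.03 log units; within the scatter) stayed within the scatter. On that basis compound 4 is estimated at 1.2 10^-6 cm/s, with a likely range from 0.5 10^-6 cm/s to 2.5 10^-6 cm/s.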

Compound 4, apparent permeability: 4.6 10^-6 cm/s
Beside the measured number, compound 4's estimate is 3.8-fold (0.58 log units) below it; the measured number lies above the stated range.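

The same kind of change, carboxymethyl in place of carboxy, gave a 1.1-fold lower number from compound 1 to compound 2 (0.03 log units; within the scatter) on a saturated chain carbon bound to an aromatic nitrogen, whereas in this assay it gave a 4.6-fold higher number from compound 3 to compound 4 (0.66 log units; beyond the scatter) on a saturated chain carbon bound to an aromatic carbon. This shows that, in these two pairs, a result within the scatter in one setting did not carry over to the other: the change has to be judged in its own place and on its own core, not copied from a related pair. It does not show whether the different outcome belongs to the place of the change, to the other acid chain on the core, or to both, and no measurement shown offers an explanation for the larger step.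

The compounds shown leave open whether a still longer chain carrying the acid at the same place would move the number further, or back again, while the other chain stays as in compound 4. They also leave open what would happen if a primary amide or a methyl ester took the place of the carboxylic acid on that chain.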